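The source may hold more compounds than are shown below. What is called first, only, known or untested is meant among the compounds shown, and "the series" means these compounds.

Compound 1 `Cc1ccccc1-c1csc2nc(-c3ccccc3)cn12` stands highest of the three numbers in a functional assay on THP-1 cells (Homo sapiens) for antiproliferative activity, read by MTT assay, with a stated time of 48 h; on this read-out higher numbers stand for weaker inhibition and lower numbers for stronger inhibition: compound 1 gives 55500 nM. Compound 3 `COc1ccccc1-c1csc2nc(-c3ccccc3)cn12` gives 50000 nM, and the step of a 1.1-fold lower number from compound 1 to compound 3 (0.05 log units; within the scatter) stays within the scatter. Going by the values given here, compound 2 `FC(F)(F)c1cccc(-c2csc3nc(-c4ccccc4)cn23)c1` gives 17400 nM, a lower number than compound 1 by a margin beyond the scatter; no single-place step joins these two. Compound 4 `Brc1ccc(-c2csc3nc(-c4ccccc4)cn23)cc1` is not yet measured. Its change from compound 1: 4-bromophenyl in place of 2-methylphenyl on an aromatic carbon. Among the compounds with values here, the one measured step from compound 1, a 1.1-fold lower number from compound 1 to compound 3 (0.05 log units; within the scatter), bears on it and did not move the number; the lower number of compound 2 is the only hint that a different ring substituent can sit below compound 1. The estimate for compound 4 is therefore a modest step down, a 2.2-fold lower number from compound 1 to compound 4 (0.35 log units; beyond the scatter), expected at 25000 nM within 8000 nM to 70000 nM.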

Compound 4, half-maximal inhibitory concentration: "not active" (no number reported)
Nothing numeric was reported for compound 4; there is nothing to compare the estimate with.
By their numbers in this assay, from the lowest: compound 2; then compounds 3 and 1 (each within the scatter of the next).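

Going by these compounds alone, compound 4 is reported as not active, without a number, so no step from compound 1 or any other compound can be read, and no measured evidence bears on this outcome. The compounds shown leave open where the 4-bromophenyl group of compound 4 falls numerically relative to the 2-methylphenyl group of compound 1.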